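This account rests on a few compounds, and the source may have more. Where it says the series, first, only, none or still open, it means among the compounds named here.

Of the compounds shown here, three have been measured in a functional assay on SF-295 cells (Homo sapiens) for cytotoxicity, read by sulforhodamine B assay, with a stated time of 48 h; a higher number here means that more compound is tolerated, a lower number that less compound is tolerated. Compound 1 `ClCc1ccccc1Cn1cnc2c(Cl)nc(Cl)nc21` gives 6020 nM in this assay. Compound 2 `ClCc1ccccc1Cn1cnc2c(Cl)ncnc21` gives 51300 nM in this assay. Compound 3 `ClCc1ccccc1Cn1cnc2ncnc(Cl)c21` gives 46800 nM in this assay. Compound 2 and compound 3 are built from the same atoms joined differently; how their two cores differ is not broken down here, and their numbers in this assay lie within the scatter of each other, so nothing separates them. From compound 2 to compound 1 the change is chloro in place of hydrogen on an aromatic carbon, and this single change brought an 8.5-fold lower number from compound 2 to compound 1 (0.93 log units; beyond the scatter), meaning the cells tolerate markedly less of compound 1 than of compound 2.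

Compound 4 `ClCc1ccccc1Cn1cnc2nc(Cl)nc(Cl)c21` has not yet been measured. It differs from compound 3 by chloro in place of hydrogen on an aromatic carbon, which is the same change as from compound 2 to compound 1, at a place described in the same words. Among the measured compounds shown here, a step of similar size is therefore expected for compound 4, because the only earlier example of this change gave an 8.5-fold lower number from compound 2 to compound 1 (0.93 log units; beyond the scatter). The expected step is a 7.8-fold lower number from compound 3 to compound 4 (0.89 log units; beyond the scatter). Compound 4 is estimated to give 6000 nM in this assay, with a range from 2500 nM to 15000 nM. This expectation rests on a single pair, compound 2 and compound 1, and on the two cores sharing the same atoms, so it remains uncertain.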

Compound 4, concentration lethal to 50% of the cells: 61700 nM
Compound 4: the middle estimate sits 10-fold (1.01 log units) below what was measured; measured number outside the range, above it.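

In this assay, chloro in place of hydrogen on an aromatic carbon gave a 1.3-fold higher number from compound 3 to compound 4 (0.12 log units; within the scatter), so on this core the change makes no difference that can be read above the usual spread of repeated measurements. Set beside the earlier example, the same change behaves differently on the two cores, and that gap is real rather than scatter: the same change on two cores in this assay, an 8.5-fold lower number (0.93 log units; beyond the scatter) from compound 2 to compound 1 and a 1.3-fold higher number (0.12 log units; within the scatter) from compound 3 to compound 4, 11-fold (1.05 log units) apart, beyond the scatter of two such steps. This shows that a step measured on one core cannot simply be carried over to the other in this series, even though compound 2 and compound 3 are built from the same atoms; it does not show why the cores respond differently, and two pairs cannot say which response would be more usual for other compounds in the series.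

The compounds shown carry only chloro or hydrogen at the changed place, so it remains open how an amine or a methoxy group there would behave on each core. From the compounds shown here alone, it is also open whether a fluoro group or a longer chain would show the same split between the two cores or would give similar steps on both.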